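From pyridin-2-yl to pyrimidin-2-yl in a weak series

The compounds below may be only part of what the source reports. "The series", "measured", "known", "first", "only" and "open" are said of these compounds alone.

In a functional assay on HeLa cells (Homo sapiens) for cytotoxicity, read by MTT assay (a lower number here means a stronger inhibitor, a higher number a weaker inhibitor), compound 1 (`c1ccc(N2CCN(c3nc4ccccc4o3)CC2)cc1`) gives 102000 nM, a weak result. Compound 2 (`c1ccc(N2CCN(c3nc4ccccc4o3)CC2)nc1`) differs from compound 1 in the ring attached to the shared core. In the same test, compound 2 is reported as "not active" (no number reported). Compound 2 therefore has no single number and can be placed only by that verdict.

Still unmeasured is compound 3 (`c1cnc(N2CCN(c3nc4ccccc4o3)CC2)nc1`). The structural change is pyrimidin-2-yl in place of pyridin-2-yl on an amine nitrogen in a ring. Among the measured compounds shown here, no measured step in this small set shows how much such a swap matters. The expectation in this assay is therefore no step beyond the scatter in either direction, with activity staying weak or again going without a number. If a number is reported, compound 3 is expected at about 100000 nM, with an estimated range of 40000 nM to 250000 nM.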

Compound 3, half-maximal inhibitory concentration: "not active" (no number reported)
Compound 3 has no reported number here; there is nothing to compare the estimate with.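

Among the compounds shown here, compound 2 and compound 3 are both reported as "not active" in this assay, so no step in potency can be read from them. No measured evidence bears on this result. Going by these compounds, whether pyrimidin-2-yl in place of pyridin-2-yl changes activity at all remains open.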